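Nitro to bromo on the pendant phenyl of a pyrazoline series

This account rests on a few compounds, and the source may have more. Where it says the series, first, only, none or still open, it means among the compounds named here.

Measured so far:
compound 1, `CNC(=O)c1cc(Oc2ccc(C3=NNC(c4cccc(Br)c4)C3)cc2)ccn1`: 1960 nM
compound 2, `CNC(=O)c1cc(Oc2ccc(C3=NNC(c4cccc([N+](=O)[O-])c4)C3)cc2)ccn1`: 35400 nM
compound 3, `CNC(=O)c1cc(Oc2ccc(C3CC(c4ccc([N+](=O)[O-])cc4)=NN3)cc2)ccn1`: 8030 nM

All three were run in a functional assay on MCF7 cells (Homo sapiens) for cytotoxicity, read by MTT assay, with a stated time of 72 h; on this read-out lower numbers stand for stronger inhibition and higher numbers for weaker inhibition. Compound 2 and compound 1 differ by bromo in place of nitro on an aromatic carbon, and that change gave an 18-fold lower number from compound 2 to compound 1 (1.26 log units; beyond the scatter). Compound 3 shares its atoms with compound 2 but joins them differently; the difference between the two cores is not broken down here. In this assay compound 3 gives 8030 nM, which sits between the other two.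

Compound 4, `CNC(=O)c1cc(Oc2ccc(C3CC(c4ccc(Br)cc4)=NN3)cc2)ccn1`, is not yet measured. It differs from compound 3 by bromo in place of nitro on an aromatic carbon. This is the same kind of change as that from compound 2 to compound 1, but the surroundings differ: there the bromo sits meta to a large group, here para to a large group, and the cores are not the same.

Given the large step from compound 2 to compound 1, compound 4 is expected to show a 5.4-fold lower number from compound 3 to compound 4 (0.73 log units; beyond the scatter), though with less confidence since the core and the place both differ. The estimate for compound 4 in this assay is 1500 nM, expected within 400 nM to 6000 nM.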

Compound 4, half-maximal inhibitory concentration: 15300 nM
The estimate for compound 4 lay 10-fold (1.01 log units) below the measured number, and the stated range ends below it.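

In this assay the change from 4-nitrophenyl to 4-bromophenyl gives a 1.9-fold higher number from compound 3 to compound 4 (0.28 log units; within the scatter) and does not repeat the large step seen with the core of compound 2. The two pairs differ both in the core and in the place of the group on the phenyl ring, so these data do not show which of the two accounts for the gap, and a single pair per core gives no general rule for either core. What can be said is that the effect of bromo in place of nitro does not transfer as a fixed step between these two pairs: the same change on two cores in this assay, an 18-fold lower number (1.26 log units; beyond the scatter) from compound 2 to compound 1 and a 1.9-fold higher number (0.28 log units; within the scatter) from compound 3 to compound 4, 34-fold (1.54 log units) apart, beyond the scatter of two such steps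

Still open, from the compounds shown here alone, is how the two cores compare when the same group sits at the same place on the phenyl ring. Going by these compounds alone, also open is whether other groups on that ring, such as an amine or a carboxylic acid, would follow the step seen with compound 1 or the one seen with compound 4.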